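Swapping the benzamide aryl group for a dimethoxyphenyl ring

The compounds below may be only part of what the source reports. "The series", "measured", "known", "first", "only" and "open" are said of these compounds alone.

Among the compounds with values here, the three compounds measured so far share one core and differ only in the aryl group on the carbonyl carbon of the amide. Compound 1 `O=C(Nc1cccc(-c2oc3cc(-c4ccc(F)cc4)ccc3c(=O)c2O)c1)c1ccc(Cl)cc1` gives 3670 nM in a functional assay on HeLa cells (Homo sapiens) for antiproliferative activity, read by CCK-8 assay, with a stated time of 72 h; on this read-out lower numbers stand for stronger inhibition and higher numbers for weaker inhibition. Compound 2 `O=C(Nc1cccc(-c2oc3cc(-c4ccc(F)cc4)ccc3c(=O)c2O)c1)c1ccc(F)cc1F` gives 10700 nM, and compound 3 `O=C(Nc1cccc(-c2oc3cc(-c4ccc(F)cc4)ccc3c(=O)c2O)c1)c1ccc(Br)cc1` gives 9740 nM. Compound 3 thus stands second highest of the three; its nearest neighbour is compound 2, since a 1.1-fold lower number from compound 2 to compound 3 (0.04 log units; within the scatter), while the gap to compound 1 is wider, as a 2.7-fold higher number from compound 1 to compound 3 (0.42 log units; beyond the scatter).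

Compound 4 `COc1cc(OC)cc(C(=O)Nc2cccc(-c3oc4cc(-c5ccc(F)cc5)ccc4c(=O)c3O)c2)c1` differs from compound 3 in one place: 3,5-dimethoxyphenyl in place of 4-bromophenyl on a carbonyl carbon. Within the data shown here, the steps that bear on this are the earlier changes of the same aryl group: a 2.9-fold higher number from compound 1 to compound 2 (0.46 log units; beyond the scatter) and a 1.1-fold lower number from compound 2 to compound 3 (0.04 log units; within the scatter). Both replaced one halogenated phenyl with another, and neither moved the number by more than a modest amount. Among the measured compounds shown here, no measured step introduces methoxy groups, so the direction of any change is uncertain. The author therefore expects at most a modest step, a 1.1-fold lower number from compound 3 to compound 4 (0.06 log units; within the scatter), and estimates compound 4 at 8500 nM, with a range from 3000 nM to 25000 nM.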

Compound 4, half-maximal inhibitory concentration: 2700 nM
Compound 4: the middle estimate sits 3.1-fold (0.50 log units) above what was measured; measured number below the stated range.
By their numbers in this assay, from the lowest: compounds 4 and 1 (each within the scatter of the next); then compounds 3 and 2 (each within the scatter of the next).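

Within the data shown here, at this place on the carbonyl carbon, the only aryl group without halogen gives lower numbers in this assay than two of the halogenated groups (a 3.6-fold lower number from compound 3 to compound 4 (0.56 log units; beyond the scatter) and a 4.0-fold lower number from compound 2 to compound 4 (0.60 log units; beyond the scatter)), so the site is not limited to halogenated phenyl groups and accepts a ring carrying two hydrogen-bond acceptors. Against the 4-chlorophenyl group the step stays within the scatter (a 1.4-fold lower number from compound 1 to compound 4 (0.13 log units; within the scatter)), so this assay does not separate 3,5-dimethoxyphenyl from 4-chlorophenyl. Nothing available here accounts for these differences.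

The compounds shown leave open whether a phenyl ring carrying one methoxy group would match the 3,5-dimethoxyphenyl ring. They also leave open whether a non-aromatic group on this carbonyl carbon, such as a morpholine or a longer chain ending in an amine, would be accepted.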